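Indolyl for fluorobenzoyl on the piperidine carbon

The source may report more compounds than this note shows. Statements on the series, on what has been measured and on what is new or still open speak of the compounds shown alone.

Measured compounds:
compound 1 `O=C1c2ccccc2CCCN1CCN1CCC(Oc2ccccc2)CC1` — 20.4 nM
compound 2 `O=C1c2ccccc2CCCN1CCN1CCC(Oc2ccc(Cl)cc2)CC1` — 11.8 nM
compound 3 `O=C(c1ccc(F)cc1)C1CCN(CCN2CCCc3ccccc3C2=O)CC1` — 1.66 nM

Three compounds share a core and differ only in the group on the saturated ring carbon. In an assay on isolated protein for binding affinity to 5-hydroxytryptamine receptor 7 (Homo sapiens) (on this read-out lower numbers stand for stronger inhibition and higher numbers for weaker inhibition), compound 3 stands lowest of the three numbers, with compound 2 nearest and compound 1 furthest; both steps towards it lie beyond the scatter.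

The next compound, compound 4 `O=C1c2ccccc2CCCN1CCN1CCC(n2ccc3ccccc32)CC1`, is not yet measured. Its change from compound 3 is 1H-indol-1-yl in place of (4-fluorophenyl)carbonyl on a saturated ring carbon. The measured steps that bear on this place are a 12-fold lower number from compound 1 to compound 3 (1.09 log units; beyond the scatter) and a 7.1-fold lower number from compound 2 to compound 3 (0.85 log units; beyond the scatter), both showing that the (4-fluorophenyl)carbonyl gives markedly lower numbers than the two phenoxy groups. Going by the values given here, no step shows what an indolyl group at this place does; its effect cannot be read from the series. Since the (4-fluorophenyl)carbonyl leaves, the number is expected to rise, the step of a 4.2-fold higher number from compound 3 to compound 4 (0.62 log units; beyond the scatter) being the estimate, short of a full return to the phenoxy level. For compound 4 the expected value is 7 nM, with a range from 2 nM to 30 nM.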

Compound 4, inhibition constant: 2.75 nM
Beside the measured number, compound 4's estimate is 2.5-fold (0.41 log units) above it, and the stated range covers the measured number.
By their numbers in this assay, from the lowest: compounds 3 and 4 (each within the scatter of the next); then compounds 2 and 1 (each within the scatter of the next).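

In this assay, a carbonyl on this saturated ring carbon is not needed for a low number: 1H-indol-1-yl in place of (4-fluorophenyl)carbonyl gives a 1.7-fold higher number from compound 3 to compound 4 (0.22 log units; within the scatter), so the two groups cannot be told apart here. The separation from the phenoxy groups also survives the exchange, with a 4.3-fold lower number from compound 2 to compound 4 (0.63 log units; beyond the scatter) and a 7.4-fold lower number from compound 1 to compound 4 (0.87 log units; beyond the scatter), so among these four compounds the low numbers are not tied to (4-fluorophenyl)carbonyl alone. Nothing measured here accounts for these differences.

Open, as far as these compounds go, is whether an indolyl joined through a ring carbon instead of its ring nitrogen, a chloro on the indolyl, or a primary amine at this place would stay near compound 4 in this assay. Also open, from the compounds shown here alone, is how either group behaves on a longer chain than the one in the shared core.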